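Chloro to fluoro swap on the anilide ring

The compounds below may be only part of what the source reports. "The series", "measured", "known", "first", "only" and "open" are said of these compounds alone.

Measured so far:
compound 1 `COc1ccc(NC(=O)/C=C/c2coc3cc(OC)ccc3c2=O)cc1` — > 200000 nM
compound 2 `COc1ccc2c(=O)c(/C=C/C(=O)Nc3ccc(Cl)cc3)coc2c1` — > 200000 nM

Compound 1 in a functional assay on L02 cells (Homo sapiens) for inhibition, read by MTT assay, with a stated time of 48 h (on this read-out higher numbers stand for weaker inhibition and lower numbers for stronger inhibition), returns only a limit, > 200000 nM. Compound 2 likewise returns only a limit in this assay, > 200000 nM. Both values sit at the limit of > 200000 nM in this assay, at which 2 of the 2 values shown sit, so the step that the two limits leave unreadable from compound 1 to compound 2 cannot be read. Compound 2 therefore stands at the limit itself, with no number attached to it.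

Compound 3 `COc1ccc2c(=O)c(/C=C/C(=O)Nc3ccc(F)cc3)coc2c1` differs from compound 2 by fluoro in place of chloro on an aromatic carbon. For the measured compounds named here, the only measured step, from compound 1 to compound 2, is unreadable, so no measured step bears on this halogen exchange; the two limits are all that is known of the series. The expectation for compound 3 is a further limit in this assay, with a step that the limit leaves unreadable from compound 2 to compound 3 not readable beyond the scatter. Compound 3 is estimated at 300000 nM, in a range from 100000 nM to 1000000 nM.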

Compound 3, half-maximal inhibitory concentration: > 200000 nM
Compound 3: no number, only a limit (the forecaster's own chance of this, stated with the estimate: 85%); the middle value does not contradict the limit.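

No new step can be read among compound 1, compound 2 and compound 3 in this assay, as all three values are limits and not numbers: the limit of > 200000 nM in this assay, at which 3 of the 3 values shown sit.

The compounds shown leave open whether methoxy, chloro or fluoro on that aromatic carbon makes any difference to inhibition in this assay.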